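A few compounds are considered here, and "the series" means these few. Any claim that something is new, unique, unknown or untested is made for them only; others in the source may bear on it.

Measured in a functional assay on QG-56 cells (Homo sapiens) for antiproliferative activity; on this read-out lower numbers stand for stronger inhibition and higher numbers for weaker inhibition:
Compound 1 `COc1cccc(-c2cc([N+](=O)[O-])cc3cc(C(O)(c4ccc(C#N)cc4)c4cncn4C)oc23)c1`: 38.8 nM
Compound 2 `Cn1cncc1C(O)(c1ccc(C#N)cc1)c1cc2cc([N+](=O)[O-])cc(-c3cccc(F)c3)c2o1`: 145 nM

Of these two, compound 2 has the higher number, 145 nM, and so is the weaker inhibitor in this assay. The next compound, compound 3 `Cn1cncc1C(O)(c1ccc(C#N)cc1)c1cc2cc([N+](=O)[O-])cc(-c3cccc(C#N)c3)c2o1`, has not yet been measured. It differs from compound 2 by cyano in place of fluoro on an aromatic carbon.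

For the measured compounds named here, only one measured step involves the fluoro group: a 3.7-fold higher number from compound 1 to compound 2 (0.57 log units; beyond the scatter), a modest change that goes beyond the scatter. Read in reverse, it shows that losing fluoro in favour of methoxy gave the lower number. This single pair says nothing directly about cyano, so it offers only weak guidance. A modest move toward a lower number is therefore expected, probably smaller than the measured step, and no change beyond the scatter remains quite possible. The estimated change is a 1.6-fold lower number from compound 2 to compound 3 (0.21 log units; within the scatter). For compound 3 the estimated value is 90 nM, with an expected range of 30 nM to 270 nM.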

Compound 3, half-maximal inhibitory concentration: 22.9 nM
Compound 3: middle estimate off by 3.9-fold (0.59 log units), on the high side; the whole stated range lies above it.
By their numbers in this assay, from the lowest: compounds 3 and 1 (each within the scatter of the next); then compound 2.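

In this assay, for the compounds shown here, the change from 3-fluorophenyl to 3-cyanophenyl gives a 6.3-fold lower number from compound 2 to compound 3 (0.80 log units; beyond the scatter), a step beyond the scatter and in the same direction as the one earlier step from fluoro to methoxy read in reverse. The comparison of the two non-fluoro groups gives a 1.7-fold lower number from compound 1 to compound 3 (0.23 log units; within the scatter), which lies within the scatter, so cyano and methoxy cannot be told apart at this position on the six-membered aromatic ring, although they differ in kind, and among these three compounds it is fluoro that stands apart with the higher number. Nothing available here accounts for why fluoro differs from the other two groups.

The compounds shown leave open whether the low numbers of compound 1 and compound 3 extend to other groups at this place, such as an amine, a carboxylic acid or a longer alkoxy chain. They also leave open whether cyano or methoxy would give similar numbers on another carbon of this ring, since all three compounds carry their group in the same place.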